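A few compounds are considered here, and "the series" means these few. Any claim that something is new, unique, unknown or untested is made for them only; others in the source may bear on it.

In a functional assay on HCT-116 cells (Homo sapiens) for inhibition, read by MTT assay, with a stated time of 48 h (a higher number here means a weaker inhibitor, a lower number a stronger inhibitor), three compounds with a shared core have been measured so far. Compound 1 `COCC(=O)N(Cc1ccc(OC)c(O)c1)c1cc(OC)c(OC)c(OC)c1` gives 230 nM, compound 2 `COc1ccc(CN(C(=O)C=C(C)C)c2cc(OC)c(OC)c(OC)c2)cc1O` gives 290 nM, and compound 3 `C#CC(=O)N(Cc1ccc(OC)c(O)c1)c1cc(OC)c(OC)c(OC)c1` gives 310 nM. These numbers all lie within the usual scatter of one another, so compound 3 stands level with the other two and cannot be ranked against them.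

Compound 4 `CC/C=C/C(=O)N(Cc1ccc(OC)c(O)c1)c1cc(OC)c(OC)c(OC)c1` keeps the shared core and alters only the group on the carbonyl carbon, with but-1-en-1-yl in place of ethynyl (but-1-en-1-yl in place of ethynyl on a carbonyl carbon). Three measured swaps at this same place bear on the change. Replacing methoxymethyl with 2-methylprop-1-en-1-yl gave a 1.3-fold higher number from compound 1 to compound 2 (0.10 log units; within the scatter). Replacing methoxymethyl with ethynyl gave a 1.3-fold higher number from compound 1 to compound 3 (0.13 log units; within the scatter). Among the measured compounds shown here, replacing 2-methylprop-1-en-1-yl with ethynyl gave a 1.1-fold higher number from compound 2 to compound 3 (0.03 log units; within the scatter), and this is the closest precedent, as it also connects ethynyl with a chain carrying a double bond, though run in the opposite direction.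

None of these swaps moved the number beyond the scatter, so no real shift is expected here, and the data favour no direction. The expected change is a 1.1-fold lower number from compound 3 to compound 4 (0.04 log units; within the scatter). For compound 4 the estimated value is 280 nM, with an expected range from 130 nM to 600 nM.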

Compound 4, half-maximal inhibitory concentration: 63 nM
Compound 4: middle estimate off by 4.4-fold (0.65 log units), on the high side; the whole stated range lies above it.
By their numbers in this assay, from the lowest: compound 4; then compounds 1, 2 and 3 (each within the scatter of the next).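

In this assay, the group on this carbonyl carbon turns out to matter, which the three earlier compounds, level with one another, could not show: but-1-en-1-yl gives a 4.9-fold lower number from compound 3 to compound 4 (0.69 log units; beyond the scatter), a 4.6-fold lower number from compound 2 to compound 4 (0.66 log units; beyond the scatter) and a 3.7-fold lower number from compound 1 to compound 4 (0.56 log units; beyond the scatter). The step from compound 2 is the most telling, as 2-methylprop-1-en-1-yl also carries a double bond, so compound 2 goes against any simple rule that a double bond at this place brings the lower number; among these four compounds, only the but-1-en-1-yl chain does. Nothing available here explains why this one chain stands apart.

On these data alone, it remains open whether the double bond is needed at all, which the saturated butyl chain would test, and whether a longer chain such as pent-1-en-1-yl or hex-1-en-1-yl would lower the number further or raise it again. A ring on the carbonyl carbon, such as phenyl, is a further open case, as is the question of whether the gain from but-1-en-1-yl would persist on other cell lines.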